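Series notes: pyridyl against phenyl at the core

The compounds below may be only part of what the source reports. "The series", "measured", "known", "first", "only" and "open" are said of these compounds alone.

Measured compounds:
compound 1 `O=C(O)Cc1sc(C(c2ccc(F)cc2)c2ccc(F)cc2)nc1-c1cccc(F)c1`: 80%
compound 2 `Nc1cc(-c2nc(C(c3ccc(F)cc3)c3ccc(F)cc3)sc2CC(=O)O)cc(F)n1`: 30%
compound 3 `O=C(O)Cc1sc(C(c2ccc(F)cc2)c2ccc(F)cc2)nc1-c1cc(F)cc(F)c1`: 80%

In an in vitro functional assay on HEK285-7 cells for antagonist activity at prostaglandin D2 receptor 2 (Homo sapiens), read by BRET and beta-arrestin recruitment (on this read-out lower numbers stand for smaller maximal responses and higher numbers for larger maximal responses), compound 3 gives 80%. For the measured compounds named here, the step of no change at the digits printed from compound 1 to compound 3 (within the scatter) leaves the two level, together the highest of the three numbers, whereas a number 50 percentage points higher from compound 2 to compound 3 (beyond the scatter) is large and is the only step beyond the scatter in the set. Compound 4 `Cc1cc(-c2nc(C(c3ccc(F)cc3)c3ccc(F)cc3)sc2CC(=O)O)ccn1` carries 2-methylpyridin-4-yl in place of 3,5-difluorophenyl on an aromatic carbon. Going by the values given here, the steps that bear on this are a number 50 percentage points lower from compound 1 to compound 2 (beyond the scatter) and its reverse a number 50 percentage points higher from compound 2 to compound 3 (beyond the scatter), where a 2-amino-6-fluoropyridin-4-yl group stood in place of a phenyl ring. Compound 4 returns to a pyridin-4-yl group, though with a methyl rather than the amino and fluoro of compound 2, so a decrease is expected, possibly smaller. The expected step is a number 35 percentage points lower from compound 3 to compound 4 (beyond the scatter). Compound 4 is estimated at 45%, between 25% and 70%.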

Compound 4, largest response reached (reported as efficacy), in percent of the reference or control that the assay uses: 80%
Estimate against measurement, compound 4: 35 percentage points below, outside the stated range (above it).
By their numbers in this assay, from the lowest: compound 2; then compounds 1, 3 and 4 (each within the scatter of the next).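

In this assay, a ring nitrogen at this position, next to the ring nitrogen of the core, does not by itself lower the number: the swap to 2-methylpyridin-4-yl gives no change at the digits printed from compound 3 to compound 4 (within the scatter) and also no change at the digits printed from compound 1 to compound 4 (within the scatter) in the comparison with the 3-fluorophenyl group. The low value of compound 2 therefore stays with its 2-amino-6-fluoropyridin-4-yl group, as a number 50 percentage points higher from compound 2 to compound 4 (beyond the scatter) shows. Nothing available explains this difference.

Still open, on these data alone, is whether the amino or the fluoro group on the pyridine accounts for compound 2. A pyridin-4-yl group carrying only an amine or only a fluorine would separate the two.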